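A few compounds are considered here, and "the series" means these few. Any claim that something is new, unique, unknown or untested is made for them only; others in the source may bear on it.

Measured compounds:
Compound 1, `COc1cccc(-n2cc(CO/N=C3\CC[C@]4(C)[C@@H](CC/C=C(\C)CC/C=C(\C)CCC=C(C)C)[C@](C)(O)CC[C@H]4C3(C)C)nn2)c1`: 25400 nM
Compound 2, `COc1cc(OC)c(-n2cc(CO/N=C3\CC[C@]4(C)[C@@H](CC/C=C(\C)CC/C=C(\C)CCC=C(C)C)[C@](C)(O)CC[C@H]4C3(C)C)nn2)c(OC)c1`: 14700 nM

Both compounds were tested in a functional assay on MCF7 cells (Homo sapiens) for cytotoxicity, read by MTT assay, with a stated time of 48 h; on this read-out lower numbers stand for stronger inhibition and higher numbers for weaker inhibition. Compound 1 gives 25400 nM, the higher of the two numbers shown, while its nearest neighbour compound 2 gives 14700 nM. The gap between them is a 1.7-fold lower number from compound 1 to compound 2 (0.24 log units; within the scatter), so the two cannot be ranked.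

Compound 3, `CC(C)=CCC/C(C)=C/CC/C(C)=C/CC[C@@H]1[C@@]2(C)CC/C(=N\OCc3cn(-c4ccncc4)nn3)C(C)(C)[C@@H]2CC[C@@]1(C)O`, has not yet been measured. It differs from compound 1 in one place: pyridin-4-yl in place of 3-methoxyphenyl on an aromatic nitrogen. Among the compounds with values here, the only measured step that bears on this change, a 1.7-fold lower number from compound 1 to compound 2 (0.24 log units; within the scatter), also exchanged the group on that aromatic nitrogen of the shared core and stayed within the scatter. For compound 3 a step of a 1.2-fold lower number from compound 1 to compound 3 (0.06 log units; within the scatter) is therefore expected in this assay, again no larger than the scatter, in either direction. Compound 3 is expected to give about 22000 nM, with a range from 9000 nM to 55000 nM.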

Compound 3, half-maximal inhibitory concentration: 12600 nM
Estimate against measurement, compound 3: 1.7-fold (0.24 log units) above; low and high end bracket the measured number.
By their numbers in this assay, from the lowest: compounds 3, 2 and 1 (each within the scatter of the next).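

In this assay, the exchange on the aromatic nitrogen gives a 2.0-fold lower number from compound 1 to compound 3 (0.30 log units; within the scatter), and the exchange from the trimethoxylated ring gives a 1.2-fold lower number from compound 2 to compound 3 (0.07 log units; within the scatter). Within the data shown here, until now, only two phenyl rings bearing methoxy groups had been compared at this place; these steps show that a pyridin-4-yl group, a six-membered aromatic ring with a hetero atom and no methoxy group, also leaves the number within the scatter of both. Nothing available explains why the number stays in this range.

As far as these compounds go, all three compounds carry a six-membered aromatic ring at this place, so it remains open whether an amine, a carboxylic acid or a longer carbon chain there would shift the number beyond the scatter. The shared core is also the same throughout, which leaves the effect of any change elsewhere unknown.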